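This account rests on a few compounds, and the source may have more. Where it says the series, first, only, none or still open, it means among the compounds named here.

Measured so far:
compound 1 `Cc1cccc2sc(NC(=O)CCN3CCN(CCCN(C)C)CC3)nc12` gives 570 nM in an assay on membranes from brain for displacement of a labelled ligand from Sigma non-opioid intracellular receptor 1 (Cavia porcellus), read by scintillation counting, with a stated time of 120 min; a higher number here means a weaker inhibitor, a lower number a stronger inhibitor;
compound 2 `Cc1cccc2sc(NC(=O)CCN3CCN(CC4CCCCC4)CC3)nc12` gives 35 nM in this assay.

Compound 2 holds the lowest of the two numbers: the step of a 16-fold lower number from compound 1 to compound 2 (1.21 log units; beyond the scatter) is large and beyond the scatter. Compound 3 `Cc1cccc2sc(NC(=O)CCN3CCN(c4ccccn4)CC3)nc12` has not yet been measured. It differs from compound 2 by pyridin-2-yl in place of cyclohexylmethyl on an amine nitrogen in a ring. For the measured compounds named here, the only measured step that touches this place is the one from compound 1 to compound 2, where a swap of the group on the ring amine nitrogen moved the number by a wide margin, so the place is clearly sensitive to what stands there. Going by the values given here, no measured pair shows an aromatic group bound directly to that nitrogen, so the direction is uncertain. Compound 3 is expected to give a higher number than compound 2, with an estimated step of a 5.7-fold higher number from compound 2 to compound 3 (0.76 log units; beyond the scatter). The estimate for compound 3 is 200 nM, with a range from 50 nM to 800 nM.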

Compound 3, inhibition constant: 1000 nM
For compound 3 the middle estimate is 5.0-fold (0.70 log units) below the measured one, and the stated range ends below it.
By their numbers in this assay, from the lowest: compound 2; then compounds 1 and 3 (each within the scatter of the next).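

In this assay, pyridin-2-yl on the amine nitrogen in the ring brings a 29-fold higher number from compound 2 to compound 3 (1.46 log units; beyond the scatter), so an aromatic ring bound directly to this nitrogen does not keep the low number that cyclohexylmethyl gives in compound 2. Pyridin-2-yl and 3-(dimethylamino)propyl are very different groups, yet they lie within the scatter of each other, with a 1.8-fold higher number from compound 1 to compound 3 (0.24 log units; within the scatter); of the three groups at this position, only cyclohexylmethyl stands apart. No measurement here explains this difference.

The compounds shown leave open whether the step follows from the ring nitrogen of pyridin-2-yl or from the loss of the methylene link, a question that a phenyl or a benzyl group on the same nitrogen would address. They also leave open whether a pyridin-2-ylmethyl group would come close to compound 2.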